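Chloro in Place of Fluoro on a Shared Core

The source may report more compounds than this note shows. Statements on the series, on what has been measured and on what is new or still open speak of the compounds shown alone.

Of the compounds shown here, three built on one shared core have been tested in an assay for activation of Adrenergic receptor alpha-1 (Rattus norvegicus); a lower number here means that less compound is needed, a higher number that more compound is needed for the effect. Compound 2 `COc1cc2c(cc1OC)C(CCN1CCN(c3cccc4c3OCCO4)CC1)CC2` gives 10 mg/kg, and compound 3 `c1ccc2c(c1)CC2CCCCN1CCN(c2cccc3c2OCCO3)CC1` gives 7.15 mg/kg; these two values lie within the scatter of each other. Compound 1 `Fc1cccc2c1CC2CN1CCN(c2cccc3c2OCCO3)CC1` returned only a limit, > 1.25 mg/kg, not a number. Compound 1 is therefore the one that sits at the limit of > 1.25 mg/kg in this assay, at which 1 of the 3 values shown sits. The untested compound 4 `Clc1cccc2c1CC2CN1CCN(c2cccc3c2OCCO3)CC1` differs from compound 1 in a single spot: chloro in place of fluoro on an aromatic carbon. Within the data shown here, no pair of measured compounds differing in one place exists here, so the size of such a step cannot be read from the data. With compound 1 known only as a limit, a step in either direction beyond the scatter remains possible. Compound 4 is expected to give about 5 mg/kg, between 1.5 mg/kg and 20 mg/kg, an estimated step that the limit leaves unreadable from compound 1 to compound 4.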

Compound 4, dose for half-maximal effect: 5 mg/kg
Estimate against measurement, compound 4: no gap at the digits printed, within the range that was stated.
By their numbers in this assay, from the lowest: compounds 4, 3 and 2 (each within the scatter of the next).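

Among these compounds, no step from compound 1 to compound 4 can be read, because compound 1 stands only as a limit: the limit of > 1.25 mg/kg in this assay, at which 1 of the 4 values shown sits. On these data alone, whether chloro in place of fluoro on an aromatic carbon shifts the dose needed in this assay stays open.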